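Aryl swap at the chain carbon of compound 3

The source may report more compounds than this note shows. Statements on the series, on what has been measured and on what is new or still open speak of the compounds shown alone.

Compound 3 `COc1ccc(C(=O)/C=C/c2cccc(F)c2)c2c1C=CC(C)(C)O2` stands at the limit in a functional assay on SW-620 cells (Homo sapiens) for antiproliferative activity, read by MTT assay, with a stated time of 24 h; on this read-out lower numbers stand for stronger inhibition and higher numbers for weaker inhibition: compound 3 gives > 10000 nM, a limit of the assay and not a number. Compound 1 `COc1cccc(/C=C/C(=O)c2ccc(OC)c3c2OC(C)(C)C=C3)c1` also gives only a limit, > 10000 nM. Compound 2 `COc1ccc(/C=C/C(=O)c2ccc(OC)c3c2OC(C)(C)C=C3)c(F)c1` gives 6570 nM. Across the series, (the limit of > 10000 nM in this assay, at which 2 of the 3 values shown sit); the step of an at least 1.5-fold lower number from compound 1 to compound 2 (0.18 log units; that floor lies within the scatter) and the step of an at least 1.5-fold higher number from compound 2 to compound 3 (0.18 log units; that floor lies within the scatter) are floors within the scatter, while a step that the two limits leave unreadable from compound 1 to compound 3. Compound 4 `COc1ccc(C(=O)/C=C/c2ccc(Br)cc2)c2c1C=CC(C)(C)O2` carries the change (4-bromophenyl in place of 3-fluorophenyl on a double-bonded chain carbon bound to a double-bonded chain carbon). Among the compounds with values here, no measured step exchanges the aryl group in this way, and the two aryl swaps that were measured gave no step readable beyond the scatter. Compound 4 is therefore expected to show a step that the limit leaves unreadable from compound 3 to compound 4, with an estimated value of 12000 nM and a range from 4000 nM to 40000 nM, most likely again only a limit.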

Compound 4, half-maximal inhibitory concentration: > 10000 nM
Compound 4 was reported as a limit (the forecaster's own chance of this, stated with the estimate: 60%); the middle value lies beyond the limit too.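

In this assay, 4-bromophenyl at this chain carbon adds a third aryl group without a numerical value, and a bromine-bearing ring does not lift the series off the limit: the limit of > 10000 nM in this assay, at which 3 of the 4 values shown sit. The steps that join two limits cannot be read. Within the data shown here, the only readable step is an at least 1.5-fold higher number from compound 2 to compound 4 (0.18 log units; that floor lies within the scatter), which does not separate the two compounds.

On these data alone, it remains open whether any aryl group here gives a value clearly apart from compound 2. As far as these compounds go, it also remains open whether an amine or a carboxylic acid on this ring would give a readable number.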